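A Methyl Replaces a Bromo in Compound 4

The source may hold more compounds than are shown below. What is called first, only, known or untested is meant among the compounds shown, and "the series" means these compounds.

Of the compounds shown here, three have been measured in a functional assay on MCF7 cells (Homo sapiens) for antiproliferative activity, read by sulforhodamine B assay, with a stated time of 72 h; a higher number here means a weaker inhibitor, a lower number a stronger inhibitor: compound 1 `COc1cc(Br)cc(/C=C/C(=O)c2ccc(Cl)cc2)c1O` gives 5150 nM, compound 2 `Cc1ccc(C(=O)/C=C/c2cc(Cl)ccc2O)cc1` gives 3980 nM, and compound 3 `O=C(/C=C/c1cc(Br)ccc1O)c1ccc(Br)cc1` gives 3820 nM. Compound 3 carries the lowest of the three numbers, but its gaps to compound 2 and to compound 1 both sit within the usual scatter, so no order among them can be claimed. Compound 4 `Cc1ccc(C(=O)/C=C/c2cc(Br)ccc2O)cc1` has not yet been measured in this assay. It differs from compound 3 in one place: methyl in place of bromo on an aromatic carbon. Going by the values given here, no measured pair shows this exact change, and compound 2, which carries the same methyl, gives a number close to that of compound 3. Compound 4 is therefore expected to show no step beyond the scatter, a 1.0-fold higher number from compound 3 to compound 4 (0.02 log units; within the scatter). In this assay compound 4 is estimated at 4000 nM, ranging from 2000 nM to 8000 nM.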

Compound 4, half-maximal inhibitory concentration: 2000 nM
Compound 4: middle estimate off by 2.0-fold (0.30 log units), on the high side; the measured number falls inside the stated range.
By their numbers in this assay, from the lowest: compounds 4, 3, 2 and 1 (each within the scatter of the next, the first and the last beyond it).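

In this assay the first single-place comparisons appear: methyl in place of bromo on an aromatic carbon, para to a large group, gives a 1.9-fold lower number from compound 3 to compound 4 (0.28 log units; within the scatter) while bromo in place of chloro on an aromatic carbon gives a 2.0-fold lower number from compound 2 to compound 4 (0.30 log units; within the scatter) and so neither change moves the number beyond the scatter. At this position, methyl and bromo therefore cannot be told apart in these compounds. Nothing available explains these readings. Still open, going by these compounds, is whether an amine, a carboxylic acid or a longer chain at this position would give a step beyond the scatter.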